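The source may report more compounds than this note shows. Statements on the series, on what has been measured and on what is new or still open speak of the compounds shown alone.

Compound 1 `COc1cc(-c2ncnn2-c2ccccc2)cc(OC)c1OC` gives in a functional assay on A549 cells (Homo sapiens) for antiproliferative activity, read by MTT assay, with a stated time of 72 h (on this read-out higher numbers stand for weaker inhibition and lower numbers for stronger inhibition), only a limit, > 10000 nM.
Compound 2 `COc1ccc(-n2ncnc2-c2cc(OC)c(OC)c(OC)c2)cc1` gives in this assay only a limit, > 10000 nM.
Compound 3 `COc1cc(-n2ncnc2-c2ccc(C)cc2)cc(OC)c1OC` gives in this assay 1100 nM.

Going by the values given here, compound 3 therefore stands alone as the only measured number; the two other results are limits, as the limit of > 10000 nM in this assay, at which 2 of the 3 values shown sit, records. Among the compounds with values here, the one step measured between compounds, a step that the two limits leave unreadable from compound 1 to compound 2, stays unreadable because both of its ends sit at the limit of > 10000 nM in this assay, at which 2 of the 3 values shown sit.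

Compound 4 `COc1cc(-n2ncnc2-c2ccc(Cl)c(Cl)c2)cc(OC)c1OC` differs from compound 3 by 3,4-dichlorophenyl in place of 4-methylphenyl on an aromatic carbon. Within the data shown here, none of the measured steps involves such a change, so none bears on it, and no step beyond the usual scatter is expected in this assay. Compound 4 is estimated at 1500 nM, with a range from 500 nM to 5000 nM. The expected step is a 1.4-fold higher number from compound 3 to compound 4 (0.13 log units; within the scatter).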

Compound 4, half-maximal inhibitory concentration: > 10000 nM
Compound 4 gave a limit, no number (the forecaster's own chance of this, stated with the estimate: 15%); at least 6.6-fold (0.82 log units) between middle value and limit.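

Placing 3,4-dichlorophenyl instead of 4-methylphenyl on this aromatic carbon gives an at least 9.0-fold higher number from compound 3 to compound 4 (0.95 log units; beyond the scatter) in this assay. Going by these compounds alone, this is the first readable step, and it shows that activity at this position depends on which aryl group is attached. Compound 4 gives only a limit, so the step's full size cannot be read: the limit of > 10000 nM in this assay, at which 3 of the 4 values shown sit.

As far as these compounds go, whether a phenyl ring bearing a single chlorine, an amine or an ethyl group at this place would retain the activity of compound 3 stays open. So does the question of which chlorine matters more to the step.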